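Chloro to bromo on the phenyl ring of compound 3

The source may hold more compounds than are shown below. What is called first, only, known or untested is meant among the compounds shown, and "the series" means these compounds.

In a functional assay on the whole organism (strain Wistar albino) for inhibition, with Rattus norvegicus as the target, read by paw edema, with a stated time of 2 h, at a dose of 100 mg/kg by the oral route (on this read-out lower numbers stand for less inhibition and higher numbers for more inhibition at the one dose given (going by the name of the read-out)), compound 3 `Cc1ccc2c(Cc3nn4c(CO)c(-c5ccc(Cl)cc5)nc4s3)coc2c1` gives 28.9%, the highest of the three numbers at hand. Compound 1 `Cc1ccc2c(Cc3nn4cc(-c5ccc(Br)cc5)nc4s3)coc2c1` gives 12% and compound 2 `Cc1ccc2c(Cc3nn4c(C=O)c(-c5ccc(Br)cc5)nc4s3)coc2c1` gives 11.2%, both beyond the scatter below compound 3. Going by the values given here, the only single-point step among the measured compounds, a number 0.8 percentage points lower from compound 1 to compound 2 (within the scatter), concerns a different position and a different group, so it does not bear on the change from compound 3 to compound 4 `Cc1ccc2c(Cc3nn4c(CO)c(-c5ccc(Br)cc5)nc4s3)coc2c1`: bromo in place of chloro on an aromatic carbon. Among the compounds with values here, no measured pair separates the two halogens, so nothing here points to a step in either direction beyond the scatter. Compound 4 is therefore expected to give 27%, within a range of 15% to 38%, meaning an estimated step of a number 1.9 percentage points lower from compound 3 to compound 4 (within the scatter).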

Compound 4, a percentage reported as inhibition, in the whole organism at one dose (the size of the read-out at that dose, not a potency): 13.1%
Compound 4: middle estimate off by 13.9 percentage points, on the high side; the measured number lies below the stated range.
By their numbers in this assay, from the lowest: compounds 2, 1 and 4 (each within the scatter of the next); then compound 3.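

In this assay the halogen on the phenyl ring proves to matter when hydroxymethyl is present: the step is a number 15.8 percentage points lower from compound 3 to compound 4 (beyond the scatter). With bromo held, hydroxymethyl does not stand apart from formyl, a number 1.9 percentage points higher from compound 2 to compound 4 (within the scatter), or from hydrogen, a number 1.1 percentage points higher from compound 1 to compound 4 (within the scatter). Nothing at hand explains the halogen step.

As far as these compounds go, it remains open whether chloro would also stand apart from bromo with hydrogen or formyl at that position. From the compounds shown here alone, how a fluoro on the phenyl ring or a carboxylic acid in place of hydroxymethyl would read also remains open.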